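This account rests on a few compounds, and the source may have more. Where it says the series, first, only, none or still open, it means among the compounds named here.

Compound 1 `CCOC(=O)c1c(-c2cc3ccccc3oc2=O)nn(-c2cccc(C)c2)c1C(=O)OCC` gives 52000 nM in a functional assay on A549 cells (Homo sapiens) for cytotoxicity, read by MTT assay, with a stated time of 48 h; a lower number here means a stronger inhibitor, a higher number a weaker inhibitor.
Compound 2 `CCOC(=O)c1c(-c2cc3ccccc3oc2=O)nn(-c2ccc(OC)cc2)c1C(=O)OCC` gives 86000 nM in this assay.
Compound 3 `CCOC(=O)c1c(-c2cc3ccccc3oc2=O)nn(-c2cccc(F)c2)c1C(=O)OCC` gives 59000 nM in this assay.

All three compounds share one core and differ only in the aryl group carried on the ring nitrogen. Compound 3 has the second highest of the three numbers, but its gaps to the others are small: a 1.1-fold higher number from compound 1 to compound 3 (0.05 log units; within the scatter) and a 1.5-fold lower number from compound 2 to compound 3 (0.16 log units; within the scatter), both within the scatter of this assay. Compound 4 `CCOC(=O)c1c(-c2cc3ccccc3oc2=O)nn(-c2ccc(Cl)cc2)c1C(=O)OCC` is not yet measured. The change from compound 3 is 4-chlorophenyl in place of 3-fluorophenyl on an aromatic nitrogen. Every swap of this aryl group seen so far has left this assay essentially unchanged: a 1.7-fold higher number from compound 1 to compound 2 (0.22 log units; within the scatter), a 1.1-fold higher number from compound 1 to compound 3 (0.05 log units; within the scatter) and a 1.5-fold lower number from compound 2 to compound 3 (0.16 log units; within the scatter). A halogen in place of methyl and a group moved between the 3- and 4-positions each gave only a step inside the scatter. Compound 4 is therefore expected to show no step beyond the scatter, a 1.0-fold higher number from compound 3 to compound 4 (0.01 log units; within the scatter). The estimate for compound 4 in this assay is 60000 nM, with a range from 30000 nM to 120000 nM.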

Compound 4, half-maximal inhibitory concentration: 35000 nM
Compound 4: the middle estimate sits 1.7-fold (0.23 log units) above what was measured; measured number inside the range.
By their numbers in this assay, from the lowest: compounds 4, 1, 3 and 2 (each within the scatter of the next, the first and the last beyond it).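

In this assay, this position on the ring nitrogen gives its first step beyond the scatter, though only a modest one: a 2.5-fold lower number from compound 2 to compound 4 (0.39 log units; beyond the scatter), with chloro in place of methoxy on the aromatic carbon. The other two new steps stay within the scatter, a 1.7-fold lower number from compound 3 to compound 4 (0.23 log units; within the scatter) and a 1.5-fold lower number from compound 1 to compound 4 (0.17 log units; within the scatter), so the swap to 4-chlorophenyl separates the new compound clearly only from the 4-methoxyphenyl compound. No measurement shown here bears on why this one swap stands out.

The compounds shown leave open what this position would give with an aryl ring carrying an amine or a carboxylic acid, or with a longer chain in place of the aryl ring. They also leave open whether 4-fluorophenyl would give a number close to that of 4-chlorophenyl.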